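The compounds below may be only part of what the source reports. "The series", "measured", "known", "first", "only" and "open" are said of these compounds alone.

Measured compounds in a functional assay on the whole organism for inhibition, with Rattus norvegicus as the target, read by paw edema, at a dose of 100 mg/kg by the oral route; a higher number here means more inhibition at the dose given (going by the name of the read-out), a lower number less inhibition:
compound 1 `O=C(Nc1ccccn1)c1c(O)c2cccnc2n(-c2ccccc2)c1=O` — -13.5%
compound 2 `O=C(Nc1ccccc1)c1c(O)c2cccnc2n(-c2ccccc2)c1=O` — 4.6%

For the measured compounds named here, compound 2 stands highest of the two numbers in this assay; its nearest neighbour is compound 1, and the single measured step, a number 18.1 percentage points higher from compound 1 to compound 2 (beyond the scatter), separates them.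

Compound 3 `Cc1ccc(NC(=O)c2c(O)c3cccnc3n(-c3ccccc3)c2=O)cc1` differs from compound 2 by methyl in place of hydrogen on an aromatic carbon. Going by the values given here, no measured step bears on this change: the one step in hand, a number 18.1 percentage points higher from compound 1 to compound 2 (beyond the scatter), concerns an exchange on the amide-type nitrogen, not a substituent on the aromatic ring, and gives no guide to a methyl in place of hydrogen on an aromatic carbon. With nothing in the series to argue for movement either way, the expected step of a number 3.4 percentage points higher from compound 2 to compound 3 (within the scatter) is taken as none beyond the scatter.

Compound 3 is therefore estimated at 8% in this assay. The expected range for compound 3 runs from -8% to 24%, wide enough to cover the usual scatter of a single-dose paw edema reading.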

Compound 3, a percentage reported as inhibition, in the whole organism at one dose (the size of the read-out at that dose, not a potency): -3.5%
For compound 3 the middle estimate is 11.5 percentage points above the measured one; the measured number falls inside the stated range.
By their numbers in this assay, from the lowest: compounds 1, 3 and 2 (each within the scatter of the next, the first and the last beyond it).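

In this assay, a first substituent on the phenyl ring of compound 2, methyl on the aromatic carbon para to a large group, gives a step that stays inside the noise: a number 8.1 percentage points lower from compound 2 to compound 3 (within the scatter). This single change therefore shows no effect that can be read, and it also blurs the earlier separation between the pyridin-2-yl and phenyl amides, since a number 10 percentage points higher from compound 1 to compound 3 (within the scatter), whereas a number 18.1 percentage points higher from compound 1 to compound 2 (beyond the scatter). Nothing available bears on a cause for these numbers.

On these data alone, whether a larger or different group at this position, such as a methoxy, an amine, a carboxylic acid or a longer chain, would move the reading beyond the scatter remains open. Also open, as far as these compounds go, is whether the 4-methylphenyl result carries over to methyl placed elsewhere on the ring.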